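Propargyl thioether in the trimethoxyphenyl triazole series

The source may report more compounds than this note shows. Statements on the series, on what has been measured and on what is new or still open speak of the compounds shown alone.

Measured compounds:
compound 1 `C=CCSc1nnc(-c2cc(OC)c(OC)c(OC)c2)n1N1C(=O)c2ccccc2C1=O`, compound 2 `COc1cc(-c2nnc(SCc3ccccc3Cl)n2N2C(=O)c3ccccc3C2=O)cc(OC)c1OC`.

In a functional assay on HepG2 cells (Homo sapiens) for cytotoxicity, read by MTT assay, with a stated time of 48 h (on this read-out lower numbers stand for stronger inhibition and higher numbers for weaker inhibition), compound 1 gives only a limit, > 200000 nM. In this assay compound 2 likewise gives only a limit, > 200000 nM. The step that the two limits leave unreadable from compound 1 to compound 2 is not readable because of the limit of > 200000 nM in this assay, at which 2 of the 2 values shown sit. Compound 2 therefore stands at the limit in this assay, with nothing further to place it. Compound 3 `C#CCSc1nnc(-c2cc(OC)c(OC)c(OC)c2)n1N1C(=O)c2ccccc2C1=O` differs from compound 2 by ethynyl in place of 2-chlorophenyl on a saturated chain carbon bound to a sulfur. No measured step bears on this change, and both shown values are limits. Compound 3 is expected to sit at the limit as well, with an estimated step that the limit leaves unreadable from compound 2 to compound 3 of no size beyond the scatter. For compound 3 in this assay the estimate is 300000 nM, range 100000 nM to 1000000 nM.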

Compound 3, half-maximal inhibitory concentration: > 200000 nM
Compound 3: a limit, no number; the forecaster's own chance of this, stated with the estimate: 85%; the middle value is on the limit's open side.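

No step can be read among compound 1, compound 2 and compound 3 in this assay, as each value is a limit of the assay: the limit of > 200000 nM in this assay, at which 3 of the 3 values shown sit.

The compounds shown leave open how vinyl, 2-chlorophenyl and ethynyl on a saturated chain carbon bound to a sulfur compare.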